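Pyridin-4-yl for thiazolyl amide: solubility outlook

A few compounds are considered here, and "the series" means these few. Any claim that something is new, unique, unknown or untested is made for them only; others in the source may bear on it.

Three compounds of the series carry a value in a physicochemical assay for solubility, read by nephelometry, measured as kinetic solubility, at pH 2.0; a lower number here means a less soluble compound, a higher number a more soluble compound. Compound 1 `NCc1csc(NC(=O)c2cc3ccccc3[nH]2)n1` sits at a limit of the assay, giving > 100 ug/mL in this assay. Compound 3 `COc1ccc(C(=O)Nc2nc(CN)cs2)cc1` gives 50 ug/mL in this assay. Compound 2 `Cc1csc(NC(=O)c2cc(C(C)(C)C)nn2Cc2ccccc2)n1` also sits at a limit of the assay and gives < 1.6 ug/mL in this assay. Compound 2 therefore has no number of its own, only the line (the limit of < 1.6 ug/mL in this assay, at which 1 of the 3 values shown sits), while compound 1 rests at the other end, (the limit of > 100 ug/mL in this assay, at which 1 of the 3 values shown sits); of the three, only compound 3 gives a measured number, and where compound 2 would fall relative to it cannot be placed more closely than its limit allows.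

Compound 4 `CC(C)(C)c1cc(C(=O)Nc2ccncc2)n(Cc2ccccc2)n1` is not yet measured in this assay. It differs from compound 2 in one place: pyridin-4-yl in place of 4-methyl-1,3-thiazol-2-yl on an amide-type nitrogen. For the measured compounds named here, no pair of measured compounds differing in just this way is available, so no measured step can be quoted for it.

The expectation is an upward step an at least 25-fold higher number from compound 2 to compound 4 (1.39 log units; beyond the scatter) beyond the usual scatter, an estimate rather than a measurement. For compound 4 the estimated value in this assay is 40 ug/mL, with a range from 6 ug/mL to 100 ug/mL, and with a fair chance that the assay again reports only a limit.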

Compound 4, solubility: > 100 ug/mL
Compound 4 ended at the assay's limit (the forecaster's own chance of this, stated with the estimate: 30%); middle value at least 2.5-fold (0.39 log units) from the limit.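

In this assay, pyridin-4-yl in place of 4-methyl-1,3-thiazol-2-yl gives the series its first step that can be read at a single place: an at least 62-fold higher number from compound 2 to compound 4 (1.79 log units; beyond the scatter). Compounds 1 and 3 differ from compound 2 in more than one place, so they could not tie any difference in this read-out to one change, whereas this pair leaves the rest of compound 2 untouched and shows that the group on the amide-type nitrogen alone can carry the compound across nearly the whole range shown. The size printed for the step is only a lower bound, and compound 4 is a limit of the assay and not a number: the limit of > 100 ug/mL in this assay, at which 2 of the 4 values shown sit.

On these data alone, how far compound 4 lies past its limit stays open, and so does whether a plain phenyl or pyridin-3-yl on the same amide-type nitrogen would give a step of similar size. As far as these compounds go, the step also rests on this single pair, so it remains open whether the same change would hold on a core carrying an aminomethyl group, as compound 3 does.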